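A Third Limit and One More Ring Swap

A few compounds are considered here, and "the series" means these few. Any claim that something is new, unique, unknown or untested is made for them only; others in the source may bear on it.

Compound 1 (`CC(=O)c1ccc(-c2ccc3c(C(=O)Nc4cccc(F)c4)cc(=O)[nH]c3c2)cc1`) gives > 20000 nM in a functional assay on KYSE-70 cells for antiproliferative activity against KYSE-70 cell line (Homo sapiens), read by MTT assay, with a stated time of 72 h (a higher number here means a weaker inhibitor, a lower number a stronger inhibitor), and this is a limit, not a number. Compound 2 (`COc1ccc(-c2ccc3c(C(=O)Nc4cccc(F)c4)cc(=O)[nH]c3c2)cc1`) gives > 20000 nM, again a limit. Compound 3 (`O=C(Nc1cccc(F)c1)c1cc(=O)[nH]c2cc(-c3ccc(F)nc3)ccc12`) gives > 20000 nM, also only a limit. Compound 3 therefore has no exact position in the series, and the whole set stands at the limit of > 20000 nM in this assay, at which 3 of the 3 values shown sit.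

Compound 4 (`Cc1cc(-c2ccc3c(C(=O)Nc4cccc(F)c4)cc(=O)[nH]c3c2)c(C)cc1F`) carries 4-fluoro-2,5-dimethylphenyl in place of the 6-fluoropyridin-3-yl of compound 3, on an aromatic carbon of the shared core: 4-fluoro-2,5-dimethylphenyl in place of 6-fluoropyridin-3-yl on an aromatic carbon.

The closest guides are the other changes to this aromatic group: a step that the two limits leave unreadable from compound 1 to compound 3, a step that the two limits leave unreadable from compound 2 to compound 3 and a step that the two limits leave unreadable from compound 1 to compound 2. None of these has a size that can be read, so they show no direction and no scale for a further swap. For the measured compounds named here, they show only that three different groups here left the compounds at the same limit, so no clear gain in potency is expected. The expected change is a step that the limit leaves unreadable from compound 3 to compound 4, and a further limit is the most likely report. The estimate for compound 4 is 25000 nM, with an expected range from 10000 nM to 50000 nM.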

Compound 4, half-maximal inhibitory concentration: > 20000 nM
Compound 4 was reported as a limit; the forecaster's own chance of this, stated with the estimate: 80%; the middle value lies beyond the limit too.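

In this assay compound 4 gives > 20000 nM as a limit and not a number. All four compounds are reported only as limits, so the steps from compound 1, compound 2 and compound 3 to compound 4 cannot be read. The compounds shown leave open how strong any of them is, and whether any aromatic group at this place would give a readable value.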